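Swapping Carbamoyl for Cyano on the Shared Core

The source may hold more compounds than are shown below. What is called first, only, known or untested is meant among the compounds shown, and "the series" means these compounds.

Compound 1 `C[C@@H]1CCCN1c1c(C#N)c2c(N)nc(Nc3ccn(C)n3)cc2n1C`: 6 nM
Compound 2 `C[C@@H]1CCCN1c1c(C(N)=O)c2c(N)ncnc2n1C`: 77 nM
Compound 3 `Cc1cn(C)nc1Nc1cc2c(c(N)n1)c(C#N)c(N1CCC[C@H]1C)n2C`: 63 nM

In an assay on isolated protein for binding affinity to Leucine-rich repeat serine/threonine-protein kinase 2 (Homo sapiens), read by TR-FRET and LanthaScreen, with a stated time of 2 h (on this read-out lower numbers stand for stronger inhibition and higher numbers for weaker inhibition), compound 2 stands highest of the three numbers; its nearest neighbour is compound 3, within the scatter, while compound 1 lies furthest off, beyond it. Compound 4 `C[C@@H]1CCCN1c1c(C#N)c2c(N)ncnc2n1C` differs from compound 2 by one change: cyano in place of carbamoyl on an aromatic carbon.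

For the measured compounds named here, no measured step addresses this swap. Going by the values given here, the only measured step, an 11-fold higher number from compound 1 to compound 3 (1.02 log units; beyond the scatter), concerns a methyl added elsewhere and says nothing about the carbamoyl. Compounds 1 and 3 carry the cyano group, yet they differ from compound 2 in more than one place, so their values cannot be read as the effect of this change alone. The expectation for compound 4 is therefore a step of a 1.7-fold lower number from compound 2 to compound 4 (0.23 log units; within the scatter), within the scatter. Compound 4 is estimated at 45 nM, ranging from 12 nM to 160 nM.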

Compound 4, inhibition constant: 0.4 nM
The estimate for compound 4 lay 110-fold (2.05 log units) above the measured number; the measured number lies below the stated range.
By their numbers in this assay, from the lowest: compound 4; then compound 1; then compounds 3 and 2 (each within the scatter of the next).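

At this position on the five-membered aromatic ring, the choice of group matters greatly in this assay: cyano in place of carbamoyl gives a 190-fold lower number from compound 2 to compound 4 (2.28 log units; beyond the scatter). For the compounds shown here, this is the first measured step at this position, and it shows that a swap of one small group for another, which removes the hydrogen-bond donor, can shift the number this far. No measured evidence here explains the size of this step.

Going by these compounds, whether a carboxylic acid or an aminomethyl group at this position would give a number as low remains open. So does whether swapping cyano for carbamoyl on compound 1 would produce a step of similar size.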